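This account rests on a few compounds, and the source may have more. Where it says the series, first, only, none or still open, it means among the compounds named here.

Measured so far in an in vitro functional assay on cells (Fibroblast) for agonist activity at Alpha-1D adrenergic receptor (Homo sapiens); on this read-out lower numbers stand for an effect already at smaller amounts and higher numbers for an effect only at larger amounts of compound:

compound 1 `c1ccc(-c2nc[nH]n2)c(NCC2=NCCN2)c1` gives 3.98 nM
compound 2 `CCCCn1ncnc1-c1ccccc1NCC1=NCCN1` gives 398 nM
compound 3 `Cc1nc(-c2ccccc2NCC2=NCCN2)n(C)n1` is reported only as a limit of the assay, < 5020 nM

Compound 1 stands at the lowest of the two numbers shown in this assay; its nearest neighbour is compound 2, whose number lies higher by a gap well beyond the scatter of repeated runs. The third member, compound 3, contributes no number but a limit (the limit of < 5020 nM in this assay, at which 1 of the 3 values shown sits). Among the measured compounds shown here, no two of the measured compounds differ from each other in a single place, so no measured step is available.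

Compound 4 `Cn1nccc1-c1ccccc1NCC1=NCCN1` is still to be measured. It differs from compound 1 by 1-methyl-1H-pyrazol-5-yl in place of 1H-1,2,4-triazol-3-yl on an aromatic carbon. For the measured compounds named here, the only guidance comes from compound 2, where an alkylated five-membered ring in this position gives 398 nM, far from compound 1. Compound 3 adds only a limit of the assay. On that basis the step from compound 1 to compound 4 is expected to be a clear move to higher numbers, a 75-fold higher number from compound 1 to compound 4 (1.88 log units; beyond the scatter), beyond the scatter. Compound 4 is therefore estimated at 300 nM in this assay, with a range from 50 nM to 3000 nM.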

Compound 4, half-maximal effective concentration: < 100000 nM
Compound 4 gave a limit, no number; the forecaster's own chance of this, stated with the estimate: 15%; the middle value is on the limit's open side.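

Compound 4 gives no number in this assay, only a limit of the assay: the limit of < 100000 nM in this assay, at which 1 of the 4 values shown sits.

The step between compound 1 and compound 4 therefore cannot be read. The compounds shown leave open how far 1-methyl-1H-pyrazol-5-yl in place of 1H-1,2,4-triazol-3-yl on an aromatic carbon shifts the read-out, or whether it shifts it at all.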